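This account rests on a few compounds, and the source may have more. Where it says the series, first, only, none or still open, it means among the compounds named here.

Compound 2 `CC(=O)SCC(=O)c1ccc(NS(=O)(=O)c2ccc(OCCCO)cc2)nc1` gives in a functional assay on HCT-116 cells (Homo sapiens) for cytotoxicity (on this read-out higher numbers stand for an effect only at larger amounts of compound and lower numbers for an effect already at smaller amounts), a value of 8600 nM, the highest of the three numbers measured here. Compound 1 `CC(=O)SCC(=O)c1ccc(NS(=O)(=O)c2ccc(OCCc3ccccn3)cc2)nc1` gives 750 nM, and compound 3 `COc1ccc(S(=O)(=O)Nc2ccc(C(=O)CSC(C)=O)cn2)cc1` gives 540 nM; the steps of an 11-fold higher number from compound 1 to compound 2 (1.06 log units; beyond the scatter) and a 16-fold lower number from compound 2 to compound 3 (1.20 log units; beyond the scatter) both stand beyond the scatter, while a 1.4-fold lower number from compound 1 to compound 3 (0.14 log units; within the scatter) does not. Compound 4 `COCCCOc1ccc(S(=O)(=O)Nc2ccc(C(=O)CSC(C)=O)cn2)cc1` differs from compound 2 by methyl in place of hydrogen on an oxygen on a saturated carbon. Among the measured compounds shown here, no measured step makes exactly this change, but both large steps touch the same chain on the aromatic oxygen, and each alternative to the free hydroxy gave a lower number. A lower number is therefore expected for compound 4, at the step of a 2.9-fold lower number from compound 2 to compound 4 (0.46 log units; beyond the scatter), though with wide uncertainty. Compound 4 is estimated at 3000 nM, within 800 nM to 12000 nM.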

Compound 4, half-maximal effective concentration: 5300 nM
Compound 4: the middle estimate sits 1.8-fold (0.25 log units) below what was measured; the measured number falls inside the stated range.
By their numbers in this assay, from the lowest: compounds 3 and 1 (each within the scatter of the next); then compounds 4 and 2 (each within the scatter of the next).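

In this assay, putting methyl on the chain's end oxygen gives a 1.6-fold lower number from compound 2 to compound 4 (0.21 log units; within the scatter), which is within the scatter, so the hydrogen of the free hydroxy does not account for the high number of compound 2. The methoxy-ended chain stays well apart from the other two groups, with a 9.8-fold higher number from compound 3 to compound 4 (0.99 log units; beyond the scatter) and a 7.1-fold higher number from compound 1 to compound 4 (0.85 log units; beyond the scatter). Nothing available explains why these chains behave alike.

The compounds shown leave open whether a chain ending in an amine or a carboxylic acid would give similar numbers. They also leave open how a longer chain would behave.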